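This account rests on a few compounds, and the source may have more. Where it says the series, first, only, none or still open, it means among the compounds named here.

Measured compounds:
Compound 1 `Cc1ccc(-c2csc(NC(=O)COc3ccccc3C(C)C)n2)cc1` — 55500 nM
Compound 2 `CC(C)c1ccccc1OCC(=O)Nc1nc(-c2ccc(Cl)cc2)cs1` — 53200 nM
Compound 3 `Cc1ccc(OCC(=O)Nc2nc(-c3ccc(C)cc3)cs2)cc1` — 37200 nM

The three measured compounds were tested in a functional assay on MDA-MB-468 cells (Homo sapiens) for cytotoxicity, read by MTT assay, with a stated time of 48 h; a higher number here means a weaker inhibitor, a lower number a stronger inhibitor. Compound 1 gives 55500 nM and compound 2 gives 53200 nM; these two differ by chloro in place of methyl on an aromatic carbon, and the step is a 1.0-fold lower number from compound 1 to compound 2 (0.02 log units; within the scatter). Compound 3 gives 37200 nM; the difference between the core of compound 3 and the core of compound 1 is not broken down here, and the two values lie within the scatter of each other.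

Compound 4 `Cc1ccc(-c2csc(NC(=O)COc3ccc(Cl)cc3)n2)cc1` is not yet measured. It differs from compound 3 by chloro in place of methyl on an aromatic carbon. Among the compounds with values here, this is the same change as the one from compound 1 to compound 2, made at a place described in the same words, though in compound 4 the difference cut one bond further out also reads 4-methylphenoxy to 4-chlorophenoxy. Since that earlier step, a 1.0-fold lower number from compound 1 to compound 2 (0.02 log units; within the scatter), lay within the scatter, the step from compound 3 to compound 4 in this assay is expected to be small as well, a 1.0-fold lower number from compound 3 to compound 4 (0.01 log units; within the scatter). Compound 4 is therefore estimated at 36000 nM, with a likely range from 16000 nM to 80000 nM.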

Compound 4, half-maximal inhibitory concentration: 44200 nM
Estimate against measurement, compound 4: 1.2-fold (0.09 log units) below; measured number inside the range.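

In this assay, chloro in place of methyl on an aromatic carbon again leaves the number within the scatter (a 1.2-fold higher number from compound 3 to compound 4 (0.07 log units; within the scatter)). Set beside the earlier step, the change behaves alike on both cores: (the same change on two cores in this assay, a 1.0-fold lower number (0.02 log units; within the scatter) from compound 1 to compound 2 and a 1.2-fold higher number (0.07 log units; within the scatter) from compound 3 to compound 4, 1.2-fold (0.09 log units) apart, within the scatter of two such steps). This shows that, across these two pairs, the change carries from one core to the other without a readable step, but it does not show a direction for the change, nor that it would stay this small on any other core in the series.

The compounds shown hold only methyl and chloro at this place, so what a methoxy, a nitrile, an amine or a carboxylic acid would do there remains open. Also open, from the compounds shown here alone, is whether any group at this place could move the number beyond the scatter, since both steps here stay within it.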